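This account rests on a few compounds, and the source may have more. Where it says the series, first, only, none or still open, it means among the compounds named here.

Of the compounds shown here, two have been measured in an assay on CV-1 cells with Bile acid receptor (Homo sapiens) as the target, read by a luciferase reporter; a higher number here means that more compound is needed for the effect, a lower number that less compound is needed. Compound 2 `CC(C)c1onc(-c2c(Cl)cccc2Cl)c1COc1ccc2cc(-c3cccc(C(=O)O)c3)ccc2c1` gives 130 nM in this assay. Compound 1 `CC(C)c1onc(-c2c(Cl)cccc2Cl)c1COc1ccc2cc(-c3ccc(C(=O)O)cc3)sc2c1` carries the carboxyl group at a different position on the phenyl ring and a different core; in this assay compound 1 gives 220 nM. The two numbers lie within the usual scatter of each other, so neither can be set apart from the other, and the pair differs in more than one place, so no single step can be read from them.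

Compound 3 `CC(C)c1onc(-c2c(Cl)cccc2Cl)c1COc1ccc2cc(-c3ccc(C(=O)O)cc3)ccc2c1` keeps the core of compound 2 and changes only the phenyl substitution pattern: 4-carboxyphenyl in place of 3-carboxyphenyl on an aromatic carbon. Among the measured compounds shown here, the only guide to this change is the value of compound 1, which carries the same 4-carboxyphenyl group on another core and gives 220 nM, a number that does not separate from compound 2. Compound 3 is therefore expected to stay close to compound 2, with the step from a 1.4-fold higher number from compound 2 to compound 3 (0.14 log units; within the scatter) estimated to lie within the scatter, leaning if anything toward a slightly higher number. Compound 3 is estimated at 180 nM, with a range from 70 nM to 450 nM.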

Compound 3, half-maximal effective concentration: 980 nM
Compound 3: middle estimate off by 5.4-fold (0.74 log units), on the low side; the measured number lies above the stated range.
By their numbers in this assay, from the lowest: compounds 2 and 1 (each within the scatter of the next); then compound 3.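

Exchanging 3-carboxyphenyl for 4-carboxyphenyl, with the core and the atoms unchanged, gives a 7.5-fold higher number from compound 2 to compound 3 (0.88 log units; beyond the scatter), so on the shared core of these two compounds the choice between the two groups clearly shows in the number. The same 4-carboxyphenyl group also reads differently on the two cores: in this assay compound 1 gives 220 nM, while compound 3 gives 980 nM. The number for 4-carboxyphenyl on the core of compound 1 therefore does not carry over to the core of compound 3, and a value for this group can be read only together with the core that bears it. Nothing measured here speaks to why the exchange has this size.

The compounds shown leave open whether the step follows the carboxylic acid itself or would also appear with a tetrazole or a primary amide in its place. As far as these compounds go, how 3-carboxyphenyl would read on the core of compound 1 also stays open, so it cannot yet be said whether the step between the two groups holds on both cores.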